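This account rests on a few compounds, and the source may have more. Where it says the series, first, only, none or still open, it means among the compounds named here.

In a functional assay on U-251 cells (Homo sapiens) for inhibition, read by spectrophotometry and sulforhodamine B assay, with a stated time of 48 h (a higher number here means a weaker inhibitor of growth, a lower number a stronger inhibitor of growth), compound 1 (`O=C1CS/C(=N/N=C/c2c[nH]c3ccccc23)N1c1cccc2ccccc12`) gives 72500 nM, the highest of the three numbers and so the weakest growth inhibitor measured here. Its gaps to the other two compounds lie beyond the usual scatter. Compound 2 (`S=C(N/N=C/c1c[nH]c2ccc(Br)cc12)Nc1cccc2ccccc12`) gives 7320 nM and compound 3 (`Cc1ccc(NC(=S)N/N=C/c2c[nH]c3ccccc23)cc1`) gives 8110 nM, two values within the scatter of each other.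

Compound 4 (`O=C1CS/C(=N/N=C/c2c[nH]c3ccc(Br)cc23)N1c1cccc2ccccc12`) keeps the core of compound 1 and differs from it in one place: bromo in place of hydrogen on an aromatic carbon. This places bromo in place of hydrogen on an aromatic carbon. Going by the values given here, no two measured compounds differ in one place only, so this change has no direct measurement behind it. Compound 2 carries the same bromo and gives 7320 nM, while compound 3 lacks it and gives 8110 nM. These two compounds also differ elsewhere, so they offer only weak guidance.

In this assay, a moderate step toward a lower number is therefore expected, though it could remain close to the scatter. The expected change is a 2.4-fold lower number from compound 1 to compound 4 (0.38 log units; beyond the scatter). For compound 4 the estimated value is 30000 nM, with an expected range from 10000 nM to 80000 nM.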

Compound 4, concentration for 50% growth inhibition: 48800 nM
For compound 4 the middle estimate is 1.6-fold (0.21 log units) below the measured one, and the stated range covers the measured number.
By their numbers in this assay, from the lowest: compounds 2 and 3 (each within the scatter of the next); then compounds 4 and 1 (each within the scatter of the next).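

In this assay, going by these compounds alone, bromo in place of hydrogen on an aromatic carbon gives a 1.5-fold lower number from compound 1 to compound 4 (0.17 log units; within the scatter) and thus provides the first direct reading of this change, one that the earlier compounds, none of which differed from another in one place only, could not give. On the core of compound 1, the two compounds cannot be told apart, so a bromine atom at this place, on a six-membered aromatic ring of carbon only that is part of a fused or bridged system of two rings, is accepted without a change beyond the usual scatter. The data available here offer no measurement that accounts for this outcome.

On these data alone, it remains open whether a group other than bromo at this same place, such as an amine, a methoxy group or a carboxylic acid, would move the number beyond the scatter. As far as these compounds go, it is also open whether bromo in place of hydrogen would give a step of similar size on a core other than that of compound 1.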